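Replacing a 2-Methoxyphenyl Ring with Pyridin-3-yl

The source may hold more compounds than are shown below. What is called first, only, known or untested is meant among the compounds shown, and "the series" means these compounds.

Two compounds have been measured in an assay on isolated protein for inhibition of acid ceramidase (Homo sapiens), read by LC-MS, with a stated time of 1 h; a higher number here means a weaker inhibitor, a lower number a stronger inhibitor:

compound 1 `COc1cccc(-c2cn(C(=O)NCCCCc3ccccc3)c(=O)o2)c1`: 341 nM
compound 2 `COc1ccccc1-c1cn(C(=O)NCCCCc2ccccc2)c(=O)o1`: 177 nM

Among the compounds with values here, compound 2 has the lower of the two numbers, but the only step measured, a 1.9-fold lower number from compound 1 to compound 2 (0.28 log units; within the scatter), lies within the scatter, so the two compounds cannot be told apart with confidence. Compound 3 `O=C(NCCCCc1ccccc1)n1cc(-c2cccnc2)oc1=O` differs from compound 2 by pyridin-3-yl in place of 2-methoxyphenyl on an aromatic carbon. Within the data shown here, no measured step bears directly on this change: the one step known only moves the methoxy group around the phenyl ring and leaves the ring itself intact, and its size gives little guidance. With nothing in the numbers pointing strongly either way, a modest weakening is expected for compound 3, about a 2.3-fold higher number from compound 2 to compound 3 (0.35 log units; beyond the scatter), placing the estimate at 400 nM with a plausible range from 120 nM to 1500 nM.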

Compound 3, half-maximal inhibitory concentration: 70 nM
The estimate for compound 3 lay 5.7-fold (0.76 log units) above the measured number; the whole stated range lies above it.
By their numbers in this assay, from the lowest: compound 3; then compounds 2 and 1 (each within the scatter of the next).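

Moving the methoxy group around the phenyl ring gave no readable change, but replacing the ring itself does in this assay (a 2.5-fold lower number from compound 2 to compound 3 (0.40 log units; beyond the scatter)). The comparison with the other methoxy compound points the same way (a 4.9-fold lower number from compound 1 to compound 3 (0.69 log units; beyond the scatter)), so this position accepts pyridin-3-yl, which has fewer heavy atoms than either methoxyphenyl group, and compound 3 has the lowest number of the three, with both its steps beyond the scatter. Nothing measured here explains why the number falls with this replacement.

As far as these compounds go, whether the lower number goes with the ring nitrogen or with the loss of the methoxy group stays open, and an unsubstituted phenyl ring would separate the two. Pyridin-2-yl and pyridin-4-yl would show whether the place of that nitrogen within the ring matters.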